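A few compounds are considered here, and "the series" means these few. Any claim that something is new, unique, unknown or untested is made for them only; others in the source may bear on it.

Of the compounds shown here, two that share a core have been measured in an assay on K177 cells with Neuronal acetylcholine receptor; alpha4/beta2 (Homo sapiens) as the target; a lower number here means a smaller maximal response, a higher number a larger maximal response. Compound 1 `CN1CCC[C@H]1COc1cnccc1Br` gives 14.1% in this assay. Compound 2 `Cc1ccc(OC[C@@H]2CCCN2C)cn1` gives 54.4% in this assay, the higher of the two numbers, and its gap to compound 1 lies beyond the usual scatter. The two compounds differ in more than one place, so this gap is not traced to a single change.

Compound 3 `CN1CCC[C@H]1COc1ccc(Br)nc1` has not yet been measured in this assay. It differs from compound 2 in one place: bromo in place of methyl on an aromatic carbon. The swap sits on the six-membered aromatic ring with one nitrogen. Among the compounds with values here, no measured pair isolates this swap, so the expectation rests on the two values alone; the only other bromo-bearing compound, compound 1, gives 14.1%, which points toward a lower number. A fall in this assay of about a number 24.4 percentage points lower from compound 2 to compound 3 (beyond the scatter) is expected. Compound 3 is expected to reach about 30%, within a range from 10% to 55%.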

Compound 3, largest response reached (reported as maximum), in percent of the reference or control that the assay uses: 42.5%
Estimate against measurement, compound 3: 12.5 percentage points below; measured number inside the range.
By their numbers in this assay, from the lowest: compound 1; then compound 3; then compound 2.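

In this assay, within the data shown here, this is the first pair of compounds that differ in only one place, so the swap of methyl for bromo can now be sized: on the aromatic carbon next to the ring nitrogen, para to a group of 8 heavy atoms, the change gives a number 11.9 percentage points lower from compound 2 to compound 3 (beyond the scatter), a modest step that still lies beyond the scatter. Bromo at this position therefore lowers the maximal response without removing it, as compound 3 still reaches 42.5% in this single comparison. Nothing measured here explains why the number falls.

On these data alone, it remains open whether this fall is particular to bromo or whether a chloro, a methoxy or an amine on the same carbon would give a similar number. A single pair also cannot show whether the swap behaves the same way elsewhere on the ring.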